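Swapping the Group on a Carbonyl Carbon

The source may report more compounds than this note shows. Statements on the series, on what has been measured and on what is new or still open speak of the compounds shown alone.

Compound 1 `Cc1nc(S(C)(=O)=O)ccc1Oc1ncnc(OC2CCN(C(=O)O[C@H](C)CF)CC2)c1F` and compound 2 `Cc1nc(S(C)(=O)=O)ccc1Oc1ncnc(OC2CCN(C(=O)SC3CCC3)CC2)c1F` share one core and differ only in the group attached to a carbonyl carbon. Among the compounds with values here, in a functional assay on isolated protein for inhibition of Glucose-dependent insulinotropic receptor (Rattus norvegicus), read by HTRF and cAMP accumulation (a lower number here means that less compound is needed, a higher number that more compound is needed for the effect), compound 1 gives 1520 nM, the highest of the two numbers measured so far; compound 2 gives 77.4 nM. Within the data shown here, the single measured step, a 20-fold lower number from compound 1 to compound 2 (1.29 log units; beyond the scatter), shows that an exchange at this place can move the read-out strongly. Compound 3 `Cc1nc(S(C)(=O)=O)ccc1Oc1ncnc(OC2CCN(C(=O)C(C)(F)F)CC2)c1F` arises from compound 1 by another exchange at the same place: a group of 4 heavy atoms (2 carbon, 2 fluorine; no ring) in place of a group of 5 heavy atoms (3 carbon, 1 oxygen, 1 fluorine; no ring), on a carbonyl carbon. Among the measured compounds shown here, the group entering compound 3 is not the one that entered compound 2, so that step is only a hint that this place accepts change and can reward it; there is no direct precedent for the 1,1-difluoroethyl group. A modest improvement is therefore expected for compound 3, a 1.9-fold lower number from compound 1 to compound 3 (0.28 log units; within the scatter), with wide uncertainty. Compound 3 is estimated at 800 nM, within a range from 200 nM to 3000 nM.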

Compound 3, half-maximal effective concentration: 239 nM
Estimate against measurement, compound 3: 3.3-fold (0.52 log units) above; the measured number falls inside the stated range.
By their numbers in this assay, from the lowest: compound 2; then compound 3; then compound 1.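

In this assay, replacing the group on the carbonyl carbon of compound 1 with 1,1-difluoroethyl gives a 6.4-fold lower number from compound 1 to compound 3 (0.80 log units; beyond the scatter) and beyond the scatter, so a second, different group also lowers the number at this place. The two entering groups are not equivalent, however: the exchange of cyclobutylsulfanyl for 1,1-difluoroethyl gives a 3.1-fold higher number from compound 2 to compound 3 (0.49 log units; beyond the scatter) and leaves compound 2 with the lowest number of the three. No measurement at hand explains this order.

Within the data shown here, with only three groups compared, the compounds leave open whether the ring or the sulfur of cyclobutylsulfanyl goes with the lower number in compound 2. A cyclobutyl group joined directly to the carbonyl carbon, or a cyclobutyloxy group, would separate those two features.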